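The source may hold more compounds than are shown below. What is called first, only, known or untested is meant among the compounds shown, and "the series" means these compounds.

The study concerns four compounds sharing a benzoxazole-bearing amide attached to a piperazine chain. Compound 1 has the structure `CN(C)CCN1CCN(CC(=O)Nc2ccc(-c3nc4cc(Cl)ccc4o3)cc2)CC1` and compound 2 the structure `CN(C)CCN1CCN(CC(=O)Nc2ccc(-c3nc4ccccc4o3)cc2)CC1`; compound 3 is `Cc1cc(-c2nc3cc(Cl)ccc3o2)ccc1NC(=O)CN1CCN(CCCN(C)C)CC1`, and compound 4, not yet measured, is `Cc1cc(-c2nc3ccccc3o2)ccc1NC(=O)CN1CCN(CCCN(C)C)CC1`. In an ADME assay on NIH3T3 cells (Mus musculus) for cytotoxicity, read by MTT assay, with a stated time of 24 h (a lower number here means a stronger inhibitor, a higher number a weaker inhibitor), compound 1 gives 28700 nM, and compound 2 gives 35800 nM. Compound 3, in this assay, gives 28600 nM; the three measured numbers all lie within the scatter of one another, so no order among them can be claimed.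

The change from compound 1 to compound 2 is hydrogen in place of chloro on an aromatic carbon and it made a step of a 1.2-fold higher number from compound 1 to compound 2 (0.10 log units; within the scatter). The difference between the core of compound 1 and the core of compound 3 is not broken down here. The change from compound 3 to compound 4 is hydrogen in place of chloro on an aromatic carbon, the same change as that from compound 1 to compound 2, made on the same place of the shared benzoxazole.

Because the earlier instance of this change gave a 1.2-fold higher number from compound 1 to compound 2 (0.10 log units; within the scatter), a step within the scatter, compound 4 is expected to sit close to compound 3, with an estimated step of a 1.2-fold higher number from compound 3 to compound 4 (0.08 log units; within the scatter). On that basis compound 4 is estimated to give 34000 nM in this assay, with an expected range from 20000 nM to 60000 nM.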

Compound 4, half-maximal inhibitory concentration: 33500 nM
Compound 4: middle estimate off by 1.0-fold (0.01 log units), on the high side; the measured number falls inside the stated range.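

In this assay, going from the 5-chloro-1,3-benzoxazol-2-yl group to the 1,3-benzoxazol-2-yl group on the core of compound 3 makes a step of a 1.2-fold higher number from compound 3 to compound 4 (0.07 log units; within the scatter). Set beside the same change on the core of compound 1, the new step does not stand apart from the earlier one: the same change on two cores in this assay, a 1.2-fold higher number (0.10 log units; within the scatter) from compound 1 to compound 2 and a 1.2-fold higher number (0.07 log units; within the scatter) from compound 3 to compound 4, 1.1-fold (0.03 log units) apart, within the scatter of two such steps. This shows that, across these two pairs, the change carries from one core to the other without a difference that can be told from the scatter; it does not show that hydrogen in place of chloro has any real effect in this assay, since neither step rises above the scatter, and two small steps cannot show how the two cores would compare under a change that moves the number further, or how any other core would behave.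

The compounds shown carry only chloro or hydrogen at this place, so it remains open whether a fluoro, a methoxy or a nitrile group there would give a step beyond the scatter. As far as these compounds go, it also remains open what a carboxylic acid or a morpholine in place of the dimethylamino group would do to the number in this assay.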